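A few compounds are considered here, and "the series" means these few. Any claim that something is new, unique, unknown or untested is made for them only; others in the source may bear on it.

Measured compounds in an ADME assay on HepG2 2.2.15 cells (Homo sapiens) for cytotoxicity; a lower number here means a stronger inhibitor, a higher number a weaker inhibitor:

Compound 1, `O=C1CCCC2=C1C(c1ccccc1Cl)N=C(c1cccnc1)N2`: 1120000 nM
Compound 2, `O=C1CCCC2=C1C(c1ccc(F)cc1)N=C(c1cccnc1)N2`: 281000 nM
Compound 3, `CC1(C)CC(=O)C2=C(C1)NC(c1cccnc1)=NC2c1ccccc1Cl`: 67300 nM

Compound 3 stands lowest of the three in this assay, beyond the scatter from both others. The cores of compound 1 and compound 3 differ, but that difference is not broken down here.

From compound 1 to compound 2 the change is 4-fluorophenyl in place of 2-chlorophenyl on a saturated ring carbon, and it gave a 4.0-fold lower number from compound 1 to compound 2 (0.60 log units; beyond the scatter).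

Compound 4, `CC1(C)CC(=O)C2=C(C1)NC(c1cccnc1)=NC2c1ccc(F)cc1`, is not yet measured. It differs from compound 3 by 4-fluorophenyl in place of 2-chlorophenyl on a saturated ring carbon — the same change as that from compound 1 to compound 2, at a place described in the same words.

Within the data shown here, a step of similar size is expected from compound 3 to compound 4, a 4.0-fold lower number from compound 3 to compound 4 (0.60 log units; beyond the scatter), because it rests on the single earlier instance a 4.0-fold lower number from compound 1 to compound 2 (0.60 log units; beyond the scatter). Compound 4 is therefore estimated at 17000 nM in this assay, expected between 7000 nM and 45000 nM.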

Compound 4, half-maximal inhibitory concentration: 145000 nM
For compound 4 the middle estimate is 8.5-fold (0.93 log units) below the measured one, and the stated range ends below it.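

In this assay the change to 4-fluorophenyl from 2-chlorophenyl gave a 2.2-fold higher number from compound 3 to compound 4 (0.33 log units; beyond the scatter), opposite in direction to the earlier step. The effect of this change therefore cannot be carried from one core to the other in this series: the same change on two cores in this assay, a 4.0-fold lower number (0.60 log units; beyond the scatter) from compound 1 to compound 2 and a 2.2-fold higher number (0.33 log units; beyond the scatter) from compound 3 to compound 4, 8.6-fold (0.93 log units) apart, beyond the scatter of two such steps. With one pair on each core, this does not show which part of the difference between the cores matters, nor how the change would behave on any further core.

The compounds shown leave open how a phenyl group with no halogen would read on either core. They also leave open what an amine or a carboxylic acid in place of the halogen would do.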